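The source may report more compounds than this note shows. Statements on the series, on what has been measured and on what is new or still open speak of the compounds shown alone.

Working notes on the series.

Of the compounds shown here, three have been measured in a physicochemical assay for solubility, with a stated time of 18 h, at pH 7.4; a higher number here means a more soluble compound, a lower number a less soluble compound. Compound 1 `CC(C)(C)c1ccc(Oc2ccc3c(NCCCNCc4ccco4)ccnc3c2)cc1` gives 14500 nM in this assay. Compound 2 `COc1ccc(Oc2ccc3c(NCCCNCc4cc(F)ccc4OC)ccnc3c2)cc1` gives 14500 nM in this assay, level with compound 1 at the digits shown and within the scatter of it. Compound 3 `COc1cccc(CNCCCNc2ccnc3cc(-c4ccc(C(C)(C)C)cc4)ccc23)c1O` gives 32000 nM in this assay, a gap from compound 1 that lies beyond the scatter. Compound 1 and compound 2 thus share the lowest number of the three, with compound 3 the furthest from compound 1.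

The next step is to compound 4 `CN(C)c1cccc(Oc2ccc3c(NCCCNCc4ccco4)ccnc3c2)c1`, which differs from compound 1 in a single place: 3-(dimethylamino)phenyl in place of 4-(tert-butyl)phenyl on an oxygen on an aromatic ring. For the measured compounds named here, no step between measured compounds matches this change, so the expectation rests on the values of compound 1 alone. The step from compound 1 to compound 4 in this assay is expected to be a 2.1-fold higher number from compound 1 to compound 4 (0.32 log units; beyond the scatter), an increase that may or may not exceed the scatter. Compound 4 is expected to give 30000 nM in this assay, within a range from 10000 nM to 90000 nM.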

Compound 4, solubility: 14500 nM
Compound 4: middle estimate off by 2.1-fold (0.32 log units), on the high side; measured number inside the range.
By their numbers in this assay, from the lowest: compounds 1, 2 and 4 (each within the scatter of the next); then compound 3.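

For the compounds shown here, putting 3-(dimethylamino)phenyl in place of 4-(tert-butyl)phenyl on an oxygen on an aromatic ring gives the first one-place step, and in this assay it reads no change at the digits printed from compound 1 to compound 4 (within the scatter) for this exchange. At this position, then, a group holding a nitrogen and a hydrogen-bond acceptor can stand in for one of carbon only, with the number staying level. No independent measurement accounts for this result.

Still open, as far as these compounds go, is whether any single change at this position moves the number beyond the scatter, for instance a phenyl bearing a carboxylic acid or a morpholine in place of the 4-(tert-butyl)phenyl. Also open, from the compounds shown here alone, is whether the same exchange stays level when the rest of the molecule carries a longer chain or a different amine.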